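Tert-butyl for methyl on the sulfonamide aniline

The source may hold more compounds than are shown below. What is called first, only, known or untested is meant among the compounds shown, and "the series" means these compounds.

Three compounds share a core with a sulfonamide at one end. Compound 1 `O=C(/C=C/c1cccnc1)NCCCCCc1ccc(S(=O)(=O)Nc2ccccc2)cc1` gives 28.4 nM in an assay on isolated protein for inhibition of Nicotinamide phosphoribosyltransferase (Homo sapiens), read by WST assay, with stated times of 60 min, 5 min and 30 min, in the presence of a further agent that is not named here; a higher number here means a weaker inhibitor, a lower number a stronger inhibitor. Compound 2 `O=C(/C=C/c1cccnc1)NCCCCCc1cccc(S(=O)(=O)Nc2ccccc2)c1` gives 16.5 nM. Compound 3 `Cc1ccc(NS(=O)(=O)c2cccc(CCCCCCNC(=O)/C=C/c3cccnc3)c2)cc1` gives 9.78 nM, the lowest of the three numbers: its gap to compound 2 lies within the scatter, while its gap to compound 1 lies beyond it.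

Compound 4 `CC(C)(C)c1ccc(NS(=O)(=O)c2cccc(CCCCCCNC(=O)/C=C/c3cccnc3)c2)cc1` differs from compound 3 in one place: tert-butyl in place of methyl on an aromatic carbon. Among the compounds with values here, no measured pair among the three compounds tests this kind of exchange, so the data give no step to lean on. Compound 4 is therefore expected to stay near compound 3, with a step of a 1.2-fold higher number from compound 3 to compound 4 (0.09 log units; within the scatter) that is estimated to remain within the scatter of repeated runs, in either direction. On that basis compound 4 is expected to give about 12 nM in this assay, with a range from 4 nM to 40 nM reflecting the missing precedent.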

Compound 4, half-maximal inhibitory concentration: 9.47 nM
The estimate for compound 4 lay 1.3-fold (0.10 log units) above the measured number, within the range that was stated.
By their numbers in this assay, from the lowest: compounds 4, 3, 2 and 1 (each within the scatter of the next, the first and the last beyond it).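

Swapping methyl for tert-butyl at this place, para to a large group, gives the first one-place step in the series: a 1.0-fold lower number from compound 3 to compound 4 (0.01 log units; within the scatter) in this assay. The substituent on the aniline ring thus grows from 1 heavy atom to 4 heavy atoms, and compound 3 and compound 4 still cannot be told apart. At this place, then, the 4-(tert-butyl)phenyl group reads the same as the 4-methylphenyl group, and nothing shown here accounts for that sameness.

What the compounds leave open is whether a group of another kind at this place, such as an amine, a carboxylic acid or a methoxy group, would also read the same. They also leave open whether a group larger than tert-butyl, such as a phenyl ring, would do so.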